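A few compounds are considered here, and "the series" means these few. Any claim that something is new, unique, unknown or untested is made for them only; others in the source may bear on it.

Among the measured compounds shown here, in a functional assay on MDA-MB-231 cells (Homo sapiens) for cytotoxicity, read by MTT assay, with a stated time of 72 h (a lower number here means a stronger inhibitor, a higher number a weaker inhibitor), compound 2 `CN1CCN(CCCn2c3c(c4ccccc42)C(=O)c2c[n+]([O-])c4ccccc4c2C3=O)CC1` gives 390 nM, the lower of the two numbers so far, while compound 1 `O=C1c2c[n+]([O-])c3ccccc3c2C(=O)c2c1c1ccccc1n2Cc1cn(CC(O)CO)nn1` gives 1290 nM. The next analogue, compound 3 `CN1CCN(CCCCCCn2c3c(c4ccccc42)C(=O)c2c[n+]([O-])c4ccccc4c2C3=O)CC1`, keeps the core of compound 2 and changes only the side chain: 3-(4-methylpiperazin-1-yl)propyl in place of 4-methylpiperazin-1-yl on a saturated chain carbon, three bonds along the chain from an aromatic nitrogen. In words, 3-(4-methylpiperazin-1-yl)propyl stands in place of 4-methylpiperazin-1-yl on a saturated chain carbon, three bonds along the chain from an aromatic nitrogen. For the measured compounds named here, only one measured step bears on this, and only indirectly: a 3.3-fold lower number from compound 1 to compound 2 (0.52 log units; beyond the scatter). Going by the values given here, that modest step exchanged one side chain for an entirely different one, and no measured pair isolates chain length. A step of no greater size is therefore expected, with no firm direction and most likely none beyond the scatter. The expected change is a 1.3-fold lower number from compound 2 to compound 3 (0.11 log units; within the scatter). For compound 3 the estimated value is 300 nM, with an expected range of 120 nM to 750 nM.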

Compound 3, half-maximal inhibitory concentration: 2400 nM
Beside the measured number, compound 3's estimate is 8.0-fold (0.90 log units) below it; the whole stated range lies below it.
By their numbers in this assay, from the lowest: compound 2; then compounds 1 and 3 (each within the scatter of the next).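

In this assay, among the compounds shown here, the length of the chain carrying the 4-methylpiperazin-1-yl ring matters at this position: 3-(4-methylpiperazin-1-yl)propyl in place of 4-methylpiperazin-1-yl gives a 6.2-fold higher number from compound 2 to compound 3 (0.79 log units; beyond the scatter), the first measured step in which the terminal ring stays the same and only the chain changes. The lead of the piperazine side chain over the 1-(2,3-dihydroxypropyl)-1H-1,2,3-triazol-4-yl side chain is not kept at this length, with a 1.9-fold higher number from compound 1 to compound 3 (0.27 log units; within the scatter). Nothing available on these compounds accounts for the size of this change.

On these data alone, compound 2 and compound 3 mark only the two ends of a chain-length comparison, so the course of the numbers at an intermediate chain or a shorter one remains open. Also open, as far as these compounds go, is whether a morpholine or a dimethylamino group at the chain end would respond to chain length in the same way.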